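Amide aryl swap on a flavonol series: estimating compound 4

The source may report more compounds than this note shows. Statements on the series, on what has been measured and on what is new or still open speak of the compounds shown alone.

Measured so far:
compound 1 `O=C(Nc1cccc(-c2oc3cc(-c4ccc(F)cc4)ccc3c(=O)c2O)c1)c1ccccc1F` gives 7570 nM
compound 2 `Cc1ccccc1C(=O)Nc1cccc(-c2oc3cc(-c4ccc(F)cc4)ccc3c(=O)c2O)c1` gives 2280 nM
compound 3 `COc1cccc(C(=O)Nc2cccc(-c3oc4cc(-c5ccc(F)cc5)ccc4c(=O)c3O)c2)c1` gives 15300 nM

In a functional assay on MCF7 cells (Homo sapiens) for antiproliferative activity, read by CCK-8 assay, with a stated time of 72 h (on this read-out lower numbers stand for stronger inhibition and higher numbers for weaker inhibition), compound 2 holds the lowest number of the three, with a 3.3-fold lower number from compound 1 to compound 2 (0.52 log units; beyond the scatter) and a 6.7-fold higher number from compound 2 to compound 3 (0.83 log units; beyond the scatter) both beyond the scatter. Compound 4 `N#Cc1ccc(C(=O)Nc2cccc(-c3oc4cc(-c5ccc(F)cc5)ccc4c(=O)c3O)c2)cc1` has not been measured. It differs from compound 2 in one place: 4-cyanophenyl in place of 2-methylphenyl on a carbonyl carbon. Within the data shown here, the steps that bear on this change are those that also replace the aryl group on the carbonyl carbon: a 2.0-fold higher number from compound 1 to compound 3 (0.31 log units; beyond the scatter) and a 6.7-fold higher number from compound 2 to compound 3 (0.83 log units; beyond the scatter). Both times leaving the 2-methylphenyl or 2-fluorophenyl arrangement raised the number. The 4-cyanophenyl group is new to the set, so the direction is expected to be a higher number, of modest size, a 3.5-fold higher number from compound 2 to compound 4 (0.55 log units; beyond the scatter). Compound 4 is therefore estimated at 8000 nM, within 3000 nM to 25000 nM.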

Compound 4, half-maximal inhibitory concentration: 2660 nM
Compound 4: middle estimate off by 3.0-fold (0.48 log units), on the high side, outside the stated range (below it).
By their numbers in this assay, from the lowest: compounds 2 and 4 (each within the scatter of the next); then compound 1; then compound 3.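

Leaving the 2-methylphenyl group on this carbonyl carbon does not by itself raise the number: 4-cyanophenyl gives a 1.2-fold higher number from compound 2 to compound 4 (0.07 log units; within the scatter), so the earlier rise with compound 3 does not hold for every replacement. Among the aryl groups at this position, 4-cyanophenyl also gives a 5.8-fold lower number from compound 3 to compound 4 (0.76 log units; beyond the scatter) and a 2.8-fold lower number from compound 1 to compound 4 (0.45 log units; beyond the scatter). Nothing available accounts for these differences. The compounds shown leave open whether a carboxylic acid or an amine in place of the nitrile would keep the number, and whether 2-cyanophenyl would match 4-cyanophenyl.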